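The source may report more compounds than this note shows. Statements on the series, on what has been measured and on what is new or still open speak of the compounds shown alone.

In a functional assay on A549 cells (Homo sapiens) for antiproliferative activity, read by MTT assay, with a stated time of 48 h (on this read-out lower numbers stand for stronger inhibition and higher numbers for weaker inhibition), compound 1 (`CCCCCCCCCCCCOc1ccc(C(=O)/C=C/c2c(/C=C/c3ccc(OC)cc3)cc(OC)cc2OC)cc1`) gives 7.9 ug/mL, compound 2 (`CCCCCCOc1ccc(C(=O)/C=C/c2c(/C=C/c3ccc(OC)cc3)cc(OC)cc2OC)cc1`) gives 8.4 ug/mL and compound 3 (`COc1ccc(/C=C/c2cc(OC)cc(OC)c2/C=C/C(=O)c2cccc(Cl)c2)cc1`) gives 5.6 ug/mL, so compound 3 stands within the scatter of both others. Compound 4 (`COc1ccc(/C=C/c2cc(OC)cc(OC)c2/C=C/C(=O)c2ccccc2C)cc1`) carries 2-methylphenyl in place of 3-chlorophenyl on a carbonyl carbon. Within the data shown here, the only measured step, a 1.1-fold higher number from compound 1 to compound 2 (0.03 log units; within the scatter), lies within the scatter, but it concerns a saturated chain and not this group, so it bears on the change only indirectly. Among the measured compounds shown here, no measured step tests the change itself, and no shift beyond the scatter is expected in this assay. The estimated step is a 1.2-fold higher number from compound 3 to compound 4 (0.06 log units; within the scatter). The expected value for compound 4 is 6.5 ug/mL, within an estimated range of 3.2 ug/mL to 13 ug/mL.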

Compound 4, half-maximal inhibitory concentration: 5.9 ug/mL
For compound 4 the middle estimate is 1.1-fold (0.04 log units) above the measured one; the range from low to high includes it.
By their numbers in this assay, from the lowest: compounds 3, 4, 1 and 2 (each within the scatter of the next).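

In this assay the change on the carbonyl carbon gives a 1.1-fold higher number from compound 3 to compound 4 (0.02 log units; within the scatter) and so provides the first measured test of this position, where the earlier step concerned only a saturated chain. Here, 2-methylphenyl can replace 3-chlorophenyl without a shift beyond the scatter. No evidence is available to explain this result.

Since the substituent and its ring position change together, the compounds shown cannot separate the two, as 3-methylphenyl would. Going by these compounds, it also remains open whether an amine or a carboxylic acid on the phenyl ring would leave the number within the scatter.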